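The compounds below may be only part of what the source reports. "The series", "measured", "known", "first", "only" and "open" are said of these compounds alone.

Compound 1 `COc1ccc(C(=O)/C=C/c2nc3ccccc3cc2-c2ccc(OC)cc2)cc1`: in a functional assay on NCI-H460 cells (Homo sapiens) for antiproliferative activity, read by XTT assay, with a stated time of 72 h (a higher number here means a weaker inhibitor, a lower number a stronger inhibitor), compound 1 gives only a limit, > 10000 nM.
Compound 2 `COc1ccc(-c2cc3ccccc3nc2/C=C/C(=O)c2ccc(OC)cc2OC)cc1`: in this assay compound 2 gives 7040 nM.

Going by the values given here, compound 2 holds the only actual number in this assay; the other value shown is a limit. The step from compound 1 to compound 2 adds a methoxy group and gives an at least 1.4-fold lower number from compound 1 to compound 2 (0.15 log units; that floor lies within the scatter), where compound 1 sits at the limit of > 10000 nM in this assay, at which 1 of the 2 values shown sits.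

Compound 3 `COc1ccc(-c2cc3ccccc3nc2/C=C/C(=O)c2ccccn2)cc1` differs from compound 2 at the carbonyl carbon: pyridin-2-yl in place of 2,4-dimethoxyphenyl on a carbonyl carbon. Among the compounds with values here, no measured step exchanges this whole ring, so nothing bears directly on the change. The nearest indication is the step from compound 1 to compound 2, which shows that a single methoxy on this ring is tied to a move of the floor size, and compound 1, lacking that methoxy, gives only a limit. Compound 3 loses both methoxy groups and the carbon ring itself, so a somewhat higher number, possibly again a limit, is expected; the step is estimated as a 1.4-fold higher number from compound 2 to compound 3 (0.15 log units; within the scatter).

For compound 3 the estimate in this assay is 10000 nM, with a range from 3000 nM to 35000 nM.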

Compound 3, half-maximal inhibitory concentration: 6260 nM
For compound 3 the middle estimate is 1.6-fold (0.20 log units) above the measured one; measured number inside the range.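

In this assay, the change at the carbonyl carbon replaces a group of 10 heavy atoms with one of 6 and a ring of carbon only with a ring holding 1 hetero atom, and it gives a 1.1-fold lower number from compound 2 to compound 3 (0.05 log units; within the scatter). So this position accepts more than the methoxy exchange seen earlier: the whole ring can be replaced with no change beyond the scatter, and compound 3 still gives a real number with no methoxy on that ring. The step of an at least 1.5-fold lower number from compound 1 to compound 3 (0.20 log units; that floor lies within the scatter) only sets a floor, and compound 1 remains a limit, so the number of methoxy groups on this ring does not order the three compounds, with compound 1, which carries one methoxy, standing against any such trend: the limit of > 10000 nM in this assay, at which 1 of the 3 values shown sits.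

What the compounds shown leave open is whether any group on this carbonyl carbon moves the number beyond the scatter, for instance pyridin-3-yl, a plain phenyl, or a ring carrying an amine or a carboxylic acid. The double-bonded chain itself also stays unexplored, since a longer chain or a saturated one does not appear among these compounds.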